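Adding a methyl group to compound 1

The compounds below may be only part of what the source reports. "The series", "measured", "known", "first", "only" and "open" are said of these compounds alone.

In a functional assay on A2780 cells (Homo sapiens) for inhibition, read by sulforhodamine B assay (on this read-out higher numbers stand for weaker inhibition of growth and lower numbers for stronger inhibition of growth), compound 1 (`c1ccc(-c2ccc(-c3ccc(-c4nc5ccccc5[nH]4)cc3)cc2)cc1`) gives 32100 nM and stands level with compound 3 (`Oc1cccc2[nH]c(-c3ccc(-c4ccc(-c5ccccc5)cc4)cc3)nc12`) at 41000 nM on this read-out, while compound 2 (`COc1ccc(-c2ccc(-c3ccc(-c4nc5ccccc5[nH]4)cc3)cc2)cc1`) gives 100000 nM on the same read-out. Compound 4 (`Cc1ccc2[nH]c(-c3ccc(-c4ccc(-c5ccccc5)cc4)cc3)nc2c1`) differs from compound 1 by one change (methyl in place of hydrogen on an aromatic carbon): methyl in place of hydrogen on an aromatic carbon. Two measured substitutions bear on it. Hydroxy in place of hydrogen gave one step (a 1.3-fold higher number from compound 1 to compound 3 (0.11 log units; within the scatter)) and methoxy in place of hydrogen gave the other (a 3.1-fold higher number from compound 1 to compound 2 (0.49 log units; beyond the scatter)). As far as these compounds go, neither gave a lower number beyond the scatter, and methyl itself is untested here, so in this assay a small upward step or none beyond the scatter is expected. The estimated step is small (a 1.2-fold higher number from compound 1 to compound 4 (0.10 log units; within the scatter)). Compound 4 is expected at 40000 nM with an estimated range from 16000 nM to 100000 nM on this read-out.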

Compound 4, concentration for 50% growth inhibition: 41200 nM
For compound 4 the middle estimate is 1.0-fold (0.01 log units) below the measured one; the range from low to high includes it.
By their numbers in this assay, from the lowest: compounds 1, 3 and 4 (each within the scatter of the next); then compound 2.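

In this assay, methyl on the six-membered aromatic ring of carbon only, part of the fused system of two rings, gives a 1.3-fold higher number from compound 1 to compound 4 (0.11 log units; within the scatter) and so leaves the number of the parent unchanged within the scatter. This shows that a single added carbon at this place neither improves nor clearly weakens growth inhibition. Nothing measured here accounts for this result.

As far as these compounds go, whether an amine or a carboxylic acid on this same carbon would move the number beyond the scatter stays open. So does whether a longer chain there would do so.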